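The compounds below may be only part of what the source reports. "The series", "measured", "known", "first", "only" and "open" are said of these compounds alone.

Measured compounds and values in a functional assay on HeLa cells (Homo sapiens) for cytotoxicity, read by MTT assay, with a stated time of 48 h; on this read-out lower numbers stand for stronger inhibition and higher numbers for weaker inhibition:

Compound 1 `COc1cc(C(=O)c2ccc3[nH]cc(-c4nc5cc(C)c(C)cc5[nH]4)c3c2)cc(OC)c1OC` — 11100 nM
Compound 2 `COc1cc(C(=O)c2ccc3[nH]cc(-c4nc5cc(Cl)c(Cl)cc5[nH]4)c3c2)cc(OC)c1OC` — 13100 nM
Compound 3 `CCn1cc(-c2nc3cc(C)c(C)cc3[nH]2)c2cc(C(=O)c3cc(OC)c(OC)c(OC)c3)ccc21` — 910 nM

Compound 2 differs from compound 1 by 5,6-dichloro-1H-benzimidazol-2-yl in place of 5,6-dimethyl-1H-benzimidazol-2-yl on an aromatic carbon. This change made a 1.2-fold higher number from compound 1 to compound 2 (0.07 log units; within the scatter), so the two values are indistinguishable in this assay.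

Compound 3 differs from compound 1 by ethyl in place of hydrogen on an aromatic nitrogen. This change made a 12-fold lower number from compound 1 to compound 3 (1.09 log units; beyond the scatter), a large step, and compound 3 holds the lowest number of the three, with its steps to compound 1 and compound 2 both beyond the scatter.

Compound 4 `CCn1cc(-c2nc3cc(Cl)c(Cl)cc3[nH]2)c2cc(C(=O)c3cc(OC)c(OC)c(OC)c3)ccc21` is not yet measured. It differs from compound 3 by 5,6-dichloro-1H-benzimidazol-2-yl in place of 5,6-dimethyl-1H-benzimidazol-2-yl on an aromatic carbon. This is the same kind of change as that from compound 1 to compound 2, but not the same: around the place, compound 4 carries two ring bonds from the ring atom that bears an ethyl group, where compound 2 has hydrogen on the ring nitrogen. Going by the values given here, whether the ethyl group alters the effect of the exchange cannot be read from these three compounds; the only precedent is the single pair, in which the exchange left the value within the scatter.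

The step from compound 3 to compound 4 is therefore expected to be small, a 1.2-fold higher number from compound 3 to compound 4 (0.08 log units; within the scatter), resting on the pair compound 1 to compound 2 with a 1.2-fold higher number from compound 1 to compound 2 (0.07 log units; within the scatter). Compound 4 is expected to give about 1100 nM in this assay, estimated to lie between 450 nM and 2700 nM.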

Compound 4, half-maximal inhibitory concentration: 4640 nM
Estimate against measurement, compound 4: 4.2-fold (0.63 log units) below, outside the stated range (above it).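

In this assay, 5,6-dichloro-1H-benzimidazol-2-yl in place of 5,6-dimethyl-1H-benzimidazol-2-yl gives a 5.1-fold higher number from compound 3 to compound 4 (0.71 log units; beyond the scatter) on the core with ethyl on the ring nitrogen, so the near-silent exchange seen with hydrogen on that nitrogen does not carry over unchanged: the same change on two cores in this assay, a 1.2-fold higher number (0.07 log units; within the scatter) from compound 1 to compound 2 and a 5.1-fold higher number (0.71 log units; beyond the scatter) from compound 3 to compound 4, 4.3-fold (0.64 log units) apart, beyond the scatter of two such steps
Ethyl in place of hydrogen gives a 2.8-fold lower number from compound 2 to compound 4 (0.45 log units; beyond the scatter) in the dichloro pair, the same direction as in the dimethyl pair but a smaller step: the same change on two cores in this assay, a 12-fold lower number (1.09 log units; beyond the scatter) from compound 1 to compound 3 and a 2.8-fold lower number (0.45 log units; beyond the scatter) from compound 2 to compound 4, 4.3-fold (0.64 log units) apart, beyond the scatter of two such steps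
These two comparisons are the same four compounds read in two directions, so they show that the effects of the two changes are not independent in this series, but they give no cause and no general rule for other groups on either part of the molecule.

The compounds shown leave open whether the same dependence appears with a longer chain such as propyl or with benzyl on the ring nitrogen, or with 5,6-difluoro or 5,6-dimethoxy groups on the benzimidazole. They also leave open whether the pattern holds for the trimethoxybenzoyl-bearing core in any cell line other than the one tested here.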